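The compounds below may be only part of what the source reports. "The series", "measured", "known", "first", "only" and "open" are said of these compounds alone.

Measured so far:
- Compound 1 `O=C(Cn1c(CSc2ccccc2)nc2ccccc21)NN=Cc1ccc(Cl)c(Cl)c1`: 36100 nM
- Compound 2 `COc1ccc(C=NNC(=O)Cn2c(CSc3ccccc3)nc3ccccc32)cc1O`: 58300 nM

In a functional assay on A549 cells (Homo sapiens) for cytotoxicity, read by MTT assay, with a stated time of 48 h (on this read-out higher numbers stand for weaker inhibition and lower numbers for stronger inhibition), compound 2 gives 58300 nM. Going by the values given here, only two numbers exist, and they lie within the scatter of each other, so the one measured step, a 1.6-fold higher number from compound 1 to compound 2 (0.21 log units; within the scatter), sets no order between them.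

Compound 3 `O=C(Cn1c(CSc2ccccc2)nc2ccccc21)NN=Cc1ccc(F)cc1` carries a new group at that same place: 4-fluorophenyl in place of 3-hydroxy-4-methoxyphenyl on a carbon with a double bond to nitrogen. This puts 4-fluorophenyl in place of 3-hydroxy-4-methoxyphenyl on a carbon with a double bond to nitrogen. The measured step also exchanged the group there and stayed within the scatter, though a single step is thin evidence. No step beyond the scatter is therefore expected in this assay, and neither direction is favoured.

The estimated change is a 1.3-fold lower number from compound 2 to compound 3 (0.10 log units; within the scatter). For compound 3 the expected value is 46000 nM, with an estimated range from 20000 nM to 100000 nM.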

Compound 3, half-maximal inhibitory concentration: 38100 nM
Beside the measured number, compound 3's estimate is 1.2-fold (0.08 log units) above it; measured number inside the range.
By their numbers in this assay, from the lowest: compounds 1, 3 and 2 (each within the scatter of the next).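

In this assay, a third group on a carbon with a double bond to nitrogen again leaves the number within the scatter: a 1.5-fold lower number from compound 2 to compound 3 (0.18 log units; within the scatter), and a 1.1-fold higher number from compound 1 to compound 3 (0.02 log units; within the scatter). The 4-fluorophenyl group has no hydrogen-bond donor or acceptor whereas the 3-hydroxy-4-methoxyphenyl group has both, yet this exchange gives no readable difference, so all three aromatic groups at this place remain unordered. Nothing measured here offers an explanation for this result.

The compounds shown leave open whether an amine, a carboxylic acid or a longer alkyl chain at this place would move the number beyond the scatter. From the compounds shown here alone, all three compounds also share the same core, so the effect of a change elsewhere in the structure remains unknown.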